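Chloro Substitution on the Fused Core: Two Benzyl Isomers

The source may report more compounds than this note shows. Statements on the series, on what has been measured and on what is new or still open speak of the compounds shown alone.

Measured compounds, all in a functional assay on BT-549 cells (Homo sapiens) for cytotoxicity, read by sulforhodamine B assay, with a stated time of 48 h; on this read-out lower numbers stand for stronger inhibition of growth and higher numbers for weaker inhibition of growth:
compound 1 `ClCc1ccccc1Cn1cnc2c(Cl)nc(Cl)nc21`, compound 1 gives 450 nM
compound 2 `ClCc1ccccc1Cn1cnc2c(Cl)ncnc21`, compound 2 gives 1990 nM
compound 3 `ClCc1cccc(Cn2cnc3c(Cl)ncnc32)c1`, compound 3 gives 15100 nM

Compound 1 and compound 2 share one core and differ in a single place: chloro in place of hydrogen on an aromatic carbon. This change gives a 4.4-fold lower number from compound 2 to compound 1 (0.65 log units; beyond the scatter), a step beyond the usual scatter of this assay.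

Compound 2 and compound 3 carry the same atoms joined differently; the difference between the two cores is not broken down here. What the two values show is that compound 3 sits highest of the three measured numbers, with compound 2 nearest and compound 1 furthest away, both gaps beyond the scatter.

Compound 4 `ClCc1cccc(Cn2cnc3c(Cl)nc(Cl)nc32)c1` is not yet measured. It differs from compound 3 by chloro in place of hydrogen on an aromatic carbon, the same kind of change as that from compound 2 to compound 1, and the two place descriptions agree word for word. Among the compounds with values here, with only one measured instance of this change, the expectation rests on that single step. Compound 4 is therefore expected to lie lower than compound 3 by about a 4.3-fold lower number from compound 3 to compound 4 (0.63 log units; beyond the scatter), because the same change gave a 4.4-fold lower number from compound 2 to compound 1 (0.65 log units; beyond the scatter). Going by these compounds, whether the step transfers fully to the core of compound 3 is untested, so the range is kept wide. For compound 4 the estimate in this assay is 3500 nM, within 1500 nM to 9000 nM.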

Compound 4, concentration for 50% growth inhibition: 1690 nM
Compound 4: middle estimate off by 2.1-fold (0.32 log units), on the high side, and the stated range covers the measured number.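

Placing chloro in place of hydrogen on an aromatic carbon, between two ring nitrogen atoms, gives in this assay an 8.9-fold lower number from compound 3 to compound 4 (0.95 log units; beyond the scatter), so the step seen on the core of compound 2 recurs on the core of compound 3 in the same direction. The two steps cannot be told apart, and in this series the change carries from one core to the other without a measurable difference in size: the same change on two cores in this assay, a 4.4-fold lower number (0.65 log units; beyond the scatter) from compound 2 to compound 1 and an 8.9-fold lower number (0.95 log units; beyond the scatter) from compound 3 to compound 4, 2.0-fold (0.31 log units) apart, within the scatter of two such steps

Within the data shown here, this agreement rests on only two pairs, whose cores carry the same atoms joined differently, so it does not show that the step would hold on a more distant core, in another cell line or at another exposure time, and it gives no explanation for the step.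

The compounds shown leave open how an amine or a methoxy group would compare with chloro on this aromatic carbon. They also leave open whether the chloro step survives when the chloromethyl group gives way to a hydroxymethyl group or a longer chain.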